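Stretching a propyl chain to butyl

The source may report more compounds than this note shows. Statements on the series, on what has been measured and on what is new or still open speak of the compounds shown alone.

Compound 1 `CC(C)c1ccc(OC(C)(Cc2ccc(Cl)cc2)C(=O)O)cc1` and compound 2 `CCCc1ccc(CC(C)(Oc2ccc(C(C)C)cc2)C(=O)O)cc1` share a core and have both been measured in a functional assay on the whole organism for inhibition, with Rattus norvegicus as the target; a lower number here means that less compound is needed, a higher number that more compound is needed for the effect. There, compound 1 gives 1 mg/kg; 1 mg/kg; 1 mg/kg (3 entries) in each of its repeat entries, and compound 2 gives 0.5 mg/kg from a single entry. These two numbers lie within the usual scatter of each other, so compound 2 stands level with compound 1 and the data do not separate them.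

Compound 3 `CCCCc1ccc(CC(C)(Oc2ccc(C(C)C)cc2)C(=O)O)cc1` departs from compound 2 by one small edit, methyl in place of hydrogen on a saturated chain carbon, three bonds along the chain from an aromatic carbon. Read one bond further out, this is propyl to butyl. Going by the values given here, no measured pair shows a change of this kind, so its size has no direct guide. With so little altered, no shift beyond the scatter is expected in this assay, in either direction. The expectation therefore starts from compound 2 at 0.5 mg/kg. The expected outcome is no change at the digits printed from compound 2 to compound 3 (within the scatter), which stays inside the scatter. For compound 3 the estimated value is 0.5 mg/kg, with a range from 0.2 mg/kg to 1.2 mg/kg.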

Compound 3, dose for half-maximal effect: 1 mg/kg
Compound 3: the middle estimate sits 2.0-fold (0.30 log units) below what was measured; the range from low to high includes it.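

Going by these compounds alone, until now, no measured pair showed what an edit at this place does. In this assay, methyl in place of hydrogen on a saturated chain carbon, three bonds along the chain from an aromatic carbon, reads as a 2.0-fold higher number from compound 2 to compound 3 (0.30 log units; within the scatter), so the data do not separate the butyl chain from the propyl chain, and this one added carbon gives no measurable penalty or gain. Within the data shown here, this is only a single step on a single chain, and nothing measured here speaks to what lies behind the result.

The compounds shown leave open whether the chain can keep growing, for instance to pentyl or hexyl, with the number staying inside the scatter, or whether some longer chain would finally separate from propyl and butyl. They also leave open how a chain of similar size that ends in an amine or a hydroxyl group would read in this assay, which would show whether this position accepts more than plain carbon chains.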